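Replacing the pyridinylmethyl group by sec-butyl on the imine nitrogen

The compounds below may be only part of what the source reports. "The series", "measured", "known", "first", "only" and "open" are said of these compounds alone.

Compound 2 `C/C(=N\Cc1cccnc1)c1c(O)c2ccccc2oc1=O` gives the highest number of the two measured in an assay on isolated protein for inhibition of myosin-2 (Bos taurus), read by spectrophotometry, with a stated time of 24 min (on this read-out higher numbers stand for weaker inhibition and lower numbers for stronger inhibition), namely 17000 nM for compound 2. Its nearest neighbour, compound 1 `C/C(=N\Cc1cccc(C)c1)c1c(O)c2ccccc2oc1=O`, gives 4900 nM in this assay, and the step from the 3-methylphenyl to the pyridin-3-yl analogue was a 3.5-fold higher number from compound 1 to compound 2 (0.54 log units; beyond the scatter). Compound 3 `CCC(C)/N=C(\C)c1c(O)c2ccccc2oc1=O` differs from compound 2 by sec-butyl in place of (pyridin-3-yl)methyl on a double-bonded nitrogen. Among the compounds with values here, no measured step covers the loss of the aromatic ring; the only step available, a 3.5-fold higher number from compound 1 to compound 2 (0.54 log units; beyond the scatter), concerns an exchange of one ring for another and offers little guidance here. Compound 3 is therefore estimated with wide uncertainty at 9000 nM in this assay, between 3000 nM and 30000 nM. That estimate corresponds to an expected step of a 1.9-fold lower number from compound 2 to compound 3 (0.28 log units; within the scatter), which is likely to remain within the scatter.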

Compound 3, half-maximal inhibitory concentration: >= 100000 nM
Compound 3: no number, only a limit (the forecaster's own chance of this, stated with the estimate: 15%); middle value at least 11-fold (1.04 log units) away from the limit.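

In this assay, compound 3 returns only a limit of the assay and not a number: the limit of >= 100000 nM in this assay, at which 1 of the 3 values shown sits. Exchanging (pyridin-3-yl)methyl for sec-butyl on the double-bonded nitrogen is a much less tolerated kind of change than the earlier exchange of one ring for another, with an at least 5.8-fold higher number from compound 2 to compound 3 (0.76 log units; beyond the scatter). Compound 1 and compound 2, which both carry an aromatic ring in this group, give numbers, whereas compound 3, the only one of the three without such a ring, does not, so this position shows a sensitivity to the ring's removal that the first pair could not reveal.

The compounds shown do not separate the absence of the aromatic ring from the change in chain. A cyclohexylmethyl group or a longer chain such as n-hexyl on this nitrogen would leave its place in this series open.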